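Moving a Halogen on the Ketone-Side Ring

This account rests on a few compounds, and the source may have more. Where it says the series, first, only, none or still open, it means among the compounds named here.

Compound 1: `N=C(N)N/N=C/c1ccc(/C=C/C(=O)c2cccc(Br)c2)cc1` — 49.7%
Compound 2: `Cc1ccc(C(=O)/C=C/c2ccc(/C=N/NC(=N)N)cc2)cc1` — 77.7%
Compound 3: `N=C(N)N/N=C/c1ccc(/C=C/C(=O)c2ccc(Br)cc2)cc1` — 68.9%

These three compounds share one core and differ only in the ring attached to the carbonyl carbon. In a functional assay on the whole organism (Ear) for inhibition, with Mus musculus as the target, with a stated time of 30 min, at a dose of 100 mg/kg by the intraperitoneal route (a lower number here means less inhibition, a higher number more inhibition at the dose given (going by the name of the read-out)), compound 1 gives 49.7%, compound 2 gives 77.7% and compound 3 gives 68.9%. Compound 3 therefore stands clearly above compound 1, as the step of a number 19.2 percentage points higher from compound 1 to compound 3 (beyond the scatter) shows, while its gap to compound 2, a number 8.8 percentage points lower from compound 2 to compound 3 (within the scatter), lies within the scatter, so no order between compounds 2 and 3 can be claimed.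

Compound 4, `N=C(N)N/N=C/c1ccc(/C=C/C(=O)c2cccc(Cl)c2)cc1`, has not yet been measured. It differs from compound 3 in one place: 3-chlorophenyl in place of 4-bromophenyl on a carbonyl carbon. The measured step that bears on this is a number 19.2 percentage points higher from compound 1 to compound 3 (beyond the scatter), the change from a 3-bromophenyl to a 4-bromophenyl on the carbonyl carbon. Among the compounds with values here, compound 4 carries a 3-chlorophenyl where compound 1 carries a 3-bromophenyl, and no measured pair compares chlorine with bromine, so that part of the change is unanchored. The expectation is a rough reversal of the bromine step: for compound 4 the expected step is a number 16.9 percentage points lower from compound 3 to compound 4 (beyond the scatter). Compound 4 is thus estimated to give 52% in this assay, with a likely range from 38% to 68%.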

Compound 4, a percentage reported as inhibition, in the whole organism at one dose (the size of the read-out at that dose, not a potency): 80.7%
The estimate for compound 4 lay 28.7 percentage points below the measured number; the whole stated range lies below it.
By their numbers in this assay, from the lowest: compound 1; then compounds 3, 2 and 4 (each within the scatter of the next, the first and the last beyond it).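

Within the data shown here, the first direct comparison of chlorine with bromine on this ring comes with the 3-chlorophenyl group: chloro in place of bromo on an aromatic carbon gives a number 31 percentage points higher from compound 1 to compound 4 (beyond the scatter) in this assay, so the identity of the halogen matters here, even with the ring otherwise unchanged. The earlier compounds suggested that a 3-halophenyl group might be the poorer choice on the carbonyl carbon, but 3-chlorophenyl in place of 4-bromophenyl gives a number 11.8 percentage points higher from compound 3 to compound 4 (beyond the scatter), so that reading held only for bromine among these compounds. The 3-chlorophenyl and 4-methylphenyl groups cannot be ordered, since the change between them gives a number 3 percentage points higher from compound 2 to compound 4 (within the scatter), which leaves two different groups on this carbon with numbers that cannot be told apart.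

Nothing available here explains why the two halogens differ so much at this place. A 4-chlorophenyl group would show whether the same swap of halogen has the same size on the other ring position, while a plain phenyl ring or a ring carrying an amine would show how much any of these substituents contributes.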